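Benzyl-ring replacement in a nitric oxide synthase inhibitor series

The source may report more compounds than this note shows. Statements on the series, on what has been measured and on what is new or still open speak of the compounds shown alone.

Measured so far:
compound 1, `O=c1cc(CN(Cc2ccccc2)c2cnccn2)c2ccc(F)c(F)c2[nH]1`: 13 nM
compound 2, `O=c1cc(CN(Cc2ccccc2Cl)c2cnccn2)c2ccc(F)c(F)c2[nH]1`: 12 nM
compound 3, `O=c1cc(CN(Cc2ccccc2F)c2cnccn2)c2ccc(F)c(F)c2[nH]1`: 12 nM

In an assay on HEK293 cells for inhibition of Nitric oxide synthase, inducible (Homo sapiens), read by fluorescence (a higher number here means a weaker inhibitor, a lower number a stronger inhibitor), compound 3 stands level with compound 2 at the digits shown, the two lowest numbers of the set, and a 1.1-fold lower number from compound 1 to compound 3 (0.03 log units; within the scatter) and no change at the digits printed from compound 2 to compound 3 (within the scatter) are both within the scatter. Compound 4, `O=c1cc(CN(Cc2ccccn2)c2cnccn2)c2ccc(F)c(F)c2[nH]1`, differs from compound 3 by pyridin-2-yl in place of 2-fluorophenyl on a saturated chain carbon bound to a nitrogen on an aromatic ring. Among the compounds with values here, no measured step touches this exact exchange; the steps of a 1.1-fold lower number from compound 1 to compound 2 (0.03 log units; within the scatter) and a 1.1-fold lower number from compound 1 to compound 3 (0.03 log units; within the scatter) show only that changes on the benzyl ring left the number where it was. A step of similar smallness is therefore expected, with no firm direction; the expected step is a 1.3-fold higher number from compound 3 to compound 4 (0.10 log units; within the scatter). Compound 4 is estimated at 15 nM, within 6 nM to 40 nM.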

Compound 4, half-maximal inhibitory concentration: 78 nM
Estimate against measurement, compound 4: 5.2-fold (0.72 log units) below; the whole stated range lies below it.
By their numbers in this assay, from the lowest: compounds 2, 3 and 1 (each within the scatter of the next); then compound 4.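

Chloro and fluoro on the benzyl ring had left the number in place, but exchanging the ring itself does not: in this assay, pyridin-2-yl gives a 6.5-fold higher number from compound 3 to compound 4 (0.81 log units; beyond the scatter), along with a 6.5-fold higher number from compound 2 to compound 4 (0.81 log units; beyond the scatter) and a 6.0-fold higher number from compound 1 to compound 4 (0.78 log units; beyond the scatter). This position, on a saturated chain carbon bound to a nitrogen on an aromatic ring, therefore distinguishes a carbon-only ring from one with a hetero atom, whichever of the three rings is the reference. Nothing available accounts for this rise.

The compounds shown leave open whether a methoxy group or an amine on the pyridin-2-yl ring would recover the lower numbers.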